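The source may hold more compounds than are shown below. What is called first, only, known or untested is meant among the compounds shown, and "the series" means these compounds.

Measured compounds and their values:
Compound 1, `O=C(/C=C/c1ccc(OCc2cn(Cc3ccc(F)cc3)nn2)cc1)c1ccc(Br)cc1`, in a functional assay on MCF7 cells (Homo sapiens) for inhibition, read by MTT assay, with a stated time of 48 h, tested at 10 uM (a lower number here means less inhibition of growth, a higher number more inhibition of growth at the concentration tested), gives 37%.
Compound 2, `O=C(/C=C/c1ccc(OCc2cn(Cc3ccccc3Br)nn2)cc1)c1ccc([N+](=O)[O-])cc1`, gives 43%.
Compound 3, `O=C(/C=C/c1ccc(OCc2cn(Cc3ccccc3F)nn2)cc1)c1ccc([N+](=O)[O-])cc1`, gives 33%.

Compound 3 has the lowest of the three numbers, yet it lies within the scatter of both compound 1 and compound 2, so none of the three can be called more or less active than another. Going by the values given here, the only step recorded among them, a number 10 percentage points lower from compound 2 to compound 3 (within the scatter), exchanges one halogen for another on an aromatic carbon and stays within the scatter.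

Compound 4, `O=C(/C=C/c1ccc(OCc2cn(Cc3ccc(F)cc3)nn2)cc1)c1ccc([N+](=O)[O-])cc1`, has not been measured. It differs from compound 3 by 4-fluorophenyl in place of 2-fluorophenyl on a saturated chain carbon bound to an aromatic nitrogen. Among the compounds with values here, no measured step rearranges a group in this way, so none bears directly on the change. Compound 1 does carry the same 4-fluorobenzyl group as compound 4, with a different group on the other end of the molecule, and its value sits close to that of compound 3. Nothing here points to a step beyond the scatter. Compound 4 is therefore expected to give about 38%, with a likely range from 26% to 50%. That estimate corresponds to an expected step of a number 5 percentage points higher from compound 3 to compound 4 (within the scatter), within the scatter.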

Compound 4, percent growth inhibition at one concentration: 38%
Compound 4: the middle estimate sits on the measured number at the digits printed; low and high end bracket the measured number.
By their numbers in this assay, from the lowest: compounds 3, 1, 4 and 2 (each within the scatter of the next).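

In this assay, 4-fluorophenyl in place of 2-fluorophenyl, on a saturated chain carbon bound to an aromatic nitrogen, gives a number 5 percentage points higher from compound 3 to compound 4 (within the scatter), so this rearrangement of the same atoms produces no readable difference. Going by these compounds alone, the comparison with the bromine-bearing group at this place reads the same way, with a number 5 percentage points lower from compound 2 to compound 4 (within the scatter), and the first look at exchanging the bromo group for a nitro group also shows no readable difference, with a number 1 percentage points higher from compound 1 to compound 4 (within the scatter). No measurement shown here offers an explanation for these results.

Every step among these compounds stays within the scatter, so it remains open whether any change at either place can move the number beyond it. As far as these compounds go, how a plain phenyl or a phenyl carrying an amine would read at the first place, or a carboxylic acid in place of nitro at the second, also remains open.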